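The compounds below may be only part of what the source reports. "The series", "measured", "known", "first", "only" and "open" are said of these compounds alone.

Measured so far in a toxicity assay on MCF-10A cells (Homo sapiens) for cytotoxicity, read by MTT assay, with a stated time of 48 h; on this read-out lower numbers stand for stronger inhibition and higher numbers for weaker inhibition:
Compound 1, `O=C(/C=C/c1ccc2c(c1)B(O)OC2)c1cccs1`, gives 13800 nM.
Compound 2, `O=C(/C=C/c1ccc2c(c1)B(O)OC2)c1ccc(I)cc1`, reaches only the limit of this assay, > 100000 nM.
Compound 3, `O=C(/C=C/c1ccc2c(c1)B(O)OC2)c1ccccc1O`, gives 53700 nM.

Among these, compound 3 has the highest of the two proper numbers; compound 1 is nearest, and the step of a 3.9-fold higher number from compound 1 to compound 3 (0.59 log units; beyond the scatter) lies beyond the scatter. Compound 2 sits at the limit (the limit of > 100000 nM in this assay, at which 1 of the 3 values shown sits), and the step of an at least 1.8-fold lower number from compound 2 to compound 3 (0.27 log units; that floor lies within the scatter) has a floor that stays within the scatter, so the order of compound 2 and compound 3 is not settled.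

Compound 4, `Nc1cccc(C(=O)/C=C/c2ccc3c(c2)B(O)OC3)c1`, has not yet been measured. It differs from compound 3 in one place: 3-aminophenyl in place of 2-hydroxyphenyl on a carbonyl carbon. For the measured compounds named here, three measured steps bear on swapping the aryl group on this carbonyl carbon. The steps of an at least 7.2-fold higher number from compound 1 to compound 2 (0.86 log units; beyond the scatter) and a 3.9-fold higher number from compound 1 to compound 3 (0.59 log units; beyond the scatter) show that such a swap can move the number by a modest to at least modest amount, while an at least 1.8-fold lower number from compound 2 to compound 3 (0.27 log units; that floor lies within the scatter), between two phenyl variants, shows a gap whose floor stays within the scatter. Since compound 4 is a further phenyl variant, the step of a 1.1-fold lower number from compound 3 to compound 4 (0.03 log units; within the scatter) is expected to stay within the scatter. Compound 4 is therefore estimated at 50000 nM, within a range from 15000 nM to 150000 nM.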

Compound 4, half-maximal inhibitory concentration: 19600 nM
For compound 4 the middle estimate is 2.6-fold (0.41 log units) above the measured one; measured number inside the range.
By their numbers in this assay, from the lowest: compounds 1 and 4 (each within the scatter of the next); then compound 3. At a limit, above all of these: compound 2.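

In this assay, a 2.7-fold lower number from compound 3 to compound 4 (0.44 log units; beyond the scatter) shows that two phenyl variants with the same counts of heavy atoms, hydrogen-bond donors and hydrogen-bond acceptors, and no net charge, can still differ beyond the scatter, so those counts alone do not fix the number at this carbonyl carbon. With a 1.4-fold higher number from compound 1 to compound 4 (0.15 log units; within the scatter), compound 4 is also the first phenyl variant here that cannot be told apart from the thiophen-2-yl compound, so a six-membered aromatic ring in this place does not by itself separate a compound from compound 1. The step of an at least 5.1-fold lower number from compound 2 to compound 4 (0.70 log units; beyond the scatter) also clears the scatter, which the floor of the step from compound 2 to compound 3 did not, though compound 2 marks a limit and not a number: the limit of > 100000 nM in this assay, at which 1 of the 4 values shown sits.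

The three phenyl variants differ both in the group they carry and in where it sits, so these compounds cannot show which of the two changes the number. From the compounds shown here alone, how an unsubstituted phenyl, a phenyl carrying a carboxylic acid, or a longer chain on this carbonyl carbon would compare remains open.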